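The source may report more compounds than this note shows. Statements on the series, on what has been measured and on what is new or still open speak of the compounds shown alone.

In an assay on HEK293 cells for displacement of a labelled ligand from NPC1-like intracellular cholesterol transporter 1 (Homo sapiens) (a lower number here means a stronger inhibitor, a higher number a weaker inhibitor), three compounds have been measured:

Compound 1 `CCC1CCCN(C(=O)CN2CN(c3ccccc3)C3(CCN(C(=O)c4ccc(C5CCCCC5)cc4)CC3)C2=O)C1` gives 2600 nM.
Compound 2 `CCC1CCCN(C(=O)CN2CN(c3ccccc3)C3(CCN(C(=O)c4ccc(C(C)(C)C)cc4)CC3)C2=O)C1` gives 3900 nM.
Compound 3 `CS(=O)(=O)NCCCNC(=O)CN1CN(c2ccccc2)C2(CCN(C(=O)c3ccc(C4CCCCC4)cc3)CC2)C1=O` gives 3800 nM.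

Compound 4 `CC(C)(C)c1ccc(C(=O)N2CCC3(CC2)C(=O)N(CC(=O)NCCCNS(C)(=O)=O)CN3c2ccccc2)cc1` has not yet been measured. It arises from compound 3 by the change (tert-butyl in place of cyclohexyl on an aromatic carbon). The same change has already been made once among the measured compounds, from compound 1 to compound 2, as tert-butyl in place of cyclohexyl on an aromatic carbon, and there it gave a 1.5-fold higher number from compound 1 to compound 2 (0.18 log units; within the scatter). The two cores on which this change sits differ from each other by (3-(methanesulfonamido)propyl)amino in place of 3-ethylpiperidin-1-yl on a carbonyl carbon, and that core change itself gave a 1.5-fold higher number from compound 1 to compound 3 (0.16 log units; within the scatter). Because the place of the change is the same in both pairs and the earlier step of a 1.5-fold higher number from compound 1 to compound 2 (0.18 log units; within the scatter) stayed within the scatter, the step from compound 3 to compound 4 is expected to be similar, a 1.5-fold higher number from compound 3 to compound 4 (0.18 log units; within the scatter). Compound 4 is therefore estimated at 5700 nM, likely between 2500 nM and 13000 nM.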

Compound 4, half-maximal inhibitory concentration: 10400 nM
Estimate against measurement, compound 4: 1.8-fold (0.26 log units) below; the measured number falls inside the stated range.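

In this assay, tert-butyl in place of cyclohexyl on the core carrying the methanesulfonamido chain gives a 2.7-fold higher number from compound 3 to compound 4 (0.44 log units; beyond the scatter), and set beside the earlier step on the other core, this does not differ: the same change on two cores in this assay, a 1.5-fold higher number (0.18 log units; within the scatter) from compound 1 to compound 2 and a 2.7-fold higher number (0.44 log units; beyond the scatter) from compound 3 to compound 4, 1.8-fold (0.26 log units) apart, within the scatter of two such steps The swap of 3-ethylpiperidin-1-yl for the (3-(methanesulfonamido)propyl)amino group, made here on the tert-butyl compounds, gives a 2.7-fold higher number from compound 2 to compound 4 (0.43 log units; beyond the scatter), and it too matches its earlier counterpart: the same change on two cores in this assay, a 1.5-fold higher number (0.16 log units; within the scatter) from compound 1 to compound 3 and a 2.7-fold higher number (0.43 log units; beyond the scatter) from compound 2 to compound 4, 1.8-fold (0.26 log units) apart, within the scatter of two such steps This shows that each change carried across these two cores without a detectable difference, but a single pair of cores cannot show that it would do so on others.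

Still open, on these data alone, is how a phenyl or a cyclopentyl group on the same aromatic carbon would compare, and whether a carboxylic acid in place of the methanesulfonamido group would change the picture.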